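Phenyl on the five-membered ring: a dimethyl to dipropyl series

This account rests on a few compounds, and the source may have more. Where it says the series, first, only, none or still open, it means among the compounds named here.

Of the compounds shown here, three of one shared core have been measured. Compound 1 `Cn1c(=O)c2c(ccn2C)n(C)c1=O` carries methyl groups on the core and a hydrogen on the five-membered ring; in an assay for binding affinity to adenosine receptor A1 (Rattus norvegicus), in the presence of a further agent that is not named here (a higher number here means a weaker inhibitor, a lower number a stronger inhibitor), compound 1 gives 32000 nM. Compound 2 `CCCn1c(=O)c2c(ccn2C)n(CCC)c1=O` carries propyl groups in place of two of those methyls; in this assay compound 2 gives 2300 nM. Compound 3 `Cn1c(=O)c2c(cc(-c3ccccc3)n2C)n(C)c1=O` keeps the methyl groups of compound 1 and adds a phenyl; in this assay compound 3 gives 3600 nM.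

Going by the values given here, the only single-place step among the measured compounds is phenyl in place of hydrogen on an aromatic carbon which yields an 8.9-fold lower number from compound 1 to compound 3 (0.95 log units; beyond the scatter). Compound 2 differs from compound 1 in more than one place, and that difference between the two cores is not broken down here; the two values simply show compound 2 at the lower number of the pair, beyond the scatter.

Compound 4 `CCCn1c(=O)c2c(cc(-c3ccccc3)n2C)n(CCC)c1=O` is not yet measured. It stands to compound 2 as compound 3 stands to compound 1: the change is phenyl in place of hydrogen on an aromatic carbon and the place matches that of the earlier change word for word, so it is the same change. Since the earlier change gave an 8.9-fold lower number from compound 1 to compound 3 (0.95 log units; beyond the scatter), a step of similar direction is expected here, tempered by the lower starting number of compound 2 at 2300 nM; the expected step is a 5.8-fold lower number from compound 2 to compound 4 (0.76 log units; beyond the scatter). Compound 4 is therefore estimated at 400 nM in this assay, with a likely range from 120 nM to 1500 nM.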

Compound 4, inhibition constant: 110 nM
The estimate for compound 4 lay 3.6-fold (0.56 log units) above the measured number; measured number below the stated range.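

On the core of compound 2, phenyl in place of hydrogen on an aromatic carbon gives a 21-fold lower number from compound 2 to compound 4 (1.32 log units; beyond the scatter) in this assay, a large step. Set beside the earlier step, the change keeps its direction on both cores, and the two sizes cannot be told apart: the same change on two cores in this assay, an 8.9-fold lower number (0.95 log units; beyond the scatter) from compound 1 to compound 3 and a 21-fold lower number (1.32 log units; beyond the scatter) from compound 2 to compound 4, 2.4-fold (0.37 log units) apart, within the scatter of two such steps Within this series the change therefore carries over from the core of compound 1 to the core of compound 2 with no measurable difference in size, so the larger-looking second step should not be read as a real gain from the propyl groups; two steps in a single assay do not show that the change would carry over to any other core, and they do not explain why it lowers the number.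

The compounds shown hold only hydrogen or phenyl at this place and only methyl or propyl as the chains on the core, so it remains open how a phenyl bearing an amine or a carboxylic acid, or a longer chain in place of propyl, would behave. From the compounds shown here alone, whether the step holds at any other adenosine receptor also remains open.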